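A few compounds are considered here, and "the series" means these few. Any claim that something is new, unique, unknown or untested is made for them only; others in the source may bear on it.

Measured so far in a functional assay on QGY7701 cells (Homo sapiens) for cytotoxicity, read by MTT assay, with a stated time of 48 h; a higher number here means a weaker inhibitor, a lower number a stronger inhibitor:

compound 1, `Cc1cccc(Cn2cc(COc3ccc4c(=O)ccoc4c3)nn2)c1`, gives 22400 nM
compound 2, `Cc1ccc(Cn2cc(COc3ccc4c(=O)ccoc4c3)nn2)cc1`, gives 68500 nM
compound 3, `Cc1ccccc1Cn1cc(COc2ccc3c(=O)ccoc3c2)nn1`, gives > 100000 nM

For compound 3 the number is not a measured value but a limit of this assay, the one recorded as the limit of > 100000 nM in this assay, at which 1 of the 3 values shown sits. Of the three compounds it is the only one whose result is a limit rather than a number.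

Compound 4, `O=c1ccoc2cc(OCc3cn(Cc4ccccc4F)nn3)ccc12`, differs from compound 3 by fluoro in place of methyl on an aromatic carbon.

The measured steps all move the methyl from one position to another on the benzyl ring: a 3.1-fold higher number from compound 1 to compound 2 (0.49 log units; beyond the scatter), an at least 4.4-fold higher number from compound 1 to compound 3 (0.64 log units; beyond the scatter) and an at least 1.4-fold higher number from compound 2 to compound 3 (0.16 log units; that floor lies within the scatter). None of them exchanges methyl for fluoro, so they speak to the change only indirectly, by showing that compounds carrying a group in this position sit at the weak end of the set. For compound 4 the expected step is therefore a number no higher from compound 3 to compound 4 (the limit leaves the size open), nothing beyond the scatter. Compound 4 is thus expected to give about 100000 nM in this assay, within 40000 nM to 300000 nM, with a fair chance that only a limit is reported again.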

Compound 4, half-maximal inhibitory concentration: 36900 nM
Compound 4: middle estimate off by 2.7-fold (0.43 log units), on the high side, and the stated range ends above it.
By their numbers in this assay, from the lowest: compounds 1, 4 and 2 (each within the scatter of the next, the first and the last beyond it). At a limit, above all of these: compound 3.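

Exchanging 2-methylbenzyl for 2-fluorobenzyl gives an at least 2.7-fold lower number from compound 3 to compound 4 (0.43 log units; beyond the scatter) in this assay, so a group at this ring position does not by itself put a compound at the weak end of the set. Compound 3 stands at a limit, not a measured number, so this step gives only a floor: the limit of > 100000 nM in this assay, at which 1 of the 4 values shown sits. Compound 4 also falls in with the 4-methylphenyl and 3-methylphenyl compounds, with a 1.9-fold lower number from compound 2 to compound 4 (0.27 log units; within the scatter) and a 1.6-fold higher number from compound 1 to compound 4 (0.22 log units; within the scatter), so it cannot be ranked against either of them.

With only methyl and fluoro shown at this position, the compounds leave open how a chloro group, a methoxy group or an amine would read here. Going by these compounds, how far compound 3 truly lies from compound 4 also stays open.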